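Removing One Methyl from the Methoxymethyl Carbonyl Group

A few compounds are considered here, and "the series" means these few. Any claim that something is new, unique, unknown or untested is made for them only; others in the source may bear on it.

Measured so far:
- compound 1 `COCC(=O)N(Cc1ccc(OC)c(O)c1)c1cc(OC)c(OC)c(OC)c1`: 460 nM
- compound 2 `COc1cc(NCc2cccc(O)c2)cc(OC)c1OC`: 71300 nM

In a functional assay on KYSE-450 cells (Homo sapiens) for inhibition, read by MTT assay, with a stated time of 48 h (a higher number here means a weaker inhibitor, a lower number a stronger inhibitor), compound 1 has the lower number of the two, 460 nM, and its gap to compound 2 lies beyond the scatter. The next compound to be tested is compound 3 `COc1ccc(CN(C(=O)CO)c2cc(OC)c(OC)c(OC)c2)cc1O`. It differs from compound 1 by hydrogen in place of methyl on an oxygen on a saturated carbon, with hydrogen in place of methyl on an oxygen on a saturated carbon, so that methoxymethyl becomes hydroxymethyl. For the measured compounds named here, no measured pair shows this change, so the expectation rests only on compound 1 at 460 nM and on the small size of the edit. A modest rise in the number is expected, near the edge of the scatter. The estimated step is a 2.0-fold higher number from compound 1 to compound 3 (0.29 log units; within the scatter). For compound 3, the expected value in this assay is 900 nM, with an estimated range of 250 nM to 4000 nM.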

Compound 3, half-maximal inhibitory concentration: 370 nM
For compound 3 the middle estimate is 2.4-fold (0.39 log units) above the measured one; measured number inside the range.
By their numbers in this assay, from the lowest: compounds 3 and 1 (each within the scatter of the next); then compound 2.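

In this assay the change from methoxymethyl to hydroxymethyl gives a 1.2-fold lower number from compound 1 to compound 3 (0.09 log units; within the scatter) and so leaves compound 3 within the scatter of compound 1. For the compounds shown here, this is the first pair here that differs in one place, and it shows that the methyl on this oxygen can be lost without a change that this read-out can resolve. Nothing available explains this tolerance.

Going by these compounds, whether the oxygen itself matters remains open, and an amine, a carboxylic acid or a longer chain such as ethoxymethyl in this place would address that question. The contribution of the whole (hydroxymethyl)carbonyl group also remains unresolved, as compound 2 differs from compound 1 in more than one place.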